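The source may report more compounds than this note shows. Statements on the series, on what has been measured and on what is new or still open speak of the compounds shown alone.

Compound 1 `C=C[C@@](C)(/C=C/c1ccc(OCc2cn(Cc3ccc(C)cc3)nn2)cc1)CCC=C(C)C` and compound 2 `C=C[C@@](C)(/C=C/c1ccc(OCc2cn(Cc3ccc(OC)cc3)nn2)cc1)CCC=C(C)C` share one core. In a toxicity assay on RAW264.7 cells (Mus musculus) for cytotoxicity, read by MTT assay, with a stated time of 24 h (a lower number here means a stronger inhibitor, a higher number a weaker inhibitor), compound 1 gives 371000 nM, and compound 2 gives 273000 nM. The change between them is methoxy in place of methyl on an aromatic carbon, and it made a 1.4-fold lower number from compound 1 to compound 2 (0.13 log units; within the scatter).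

Compound 3 `C=C[C@@](C)(/C=C/c1ccc(OC(=O)c2cn(-c3ccc(C)cc3)nn2)cc1)CCC=C(C)C` is built on a different core; the difference between the two cores is not broken down here. In this assay compound 3 gives 37200 nM.

Within the data shown here, compound 4 `C=C[C@@](C)(/C=C/c1ccc(OC(=O)c2cn(-c3ccc(OC)cc3)nn2)cc1)CCC=C(C)C` differs from compound 3 by methoxy in place of methyl on an aromatic carbon, the same change at the same place as the one from compound 1 to compound 2. The step is expected to be small, estimated at a 1.2-fold lower number from compound 3 to compound 4 (0.09 log units; within the scatter), because a 1.4-fold lower number from compound 1 to compound 2 (0.13 log units; within the scatter) stayed within the scatter. Compound 4 is therefore expected to give about 30000 nM, with a range of 12000 nM to 90000 nM.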

Compound 4, half-maximal inhibitory concentration: 64700 nM
Compound 4: the middle estimate sits 2.2-fold (0.33 log units) below what was measured, within the range that was stated.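

In this assay, putting methoxy in place of methyl on the aromatic ring gave a 1.7-fold higher number from compound 3 to compound 4 (0.24 log units; within the scatter). Set beside the same change on the other core, the two steps do not separate: the same change on two cores in this assay, a 1.4-fold lower number (0.13 log units; within the scatter) from compound 1 to compound 2 and a 1.7-fold higher number (0.24 log units; within the scatter) from compound 3 to compound 4, 2.4-fold (0.37 log units) apart, within the scatter of two such steps. This shows that, in these two pairs, the change stayed small on both cores and neither step can be read as a real rise or fall, but it does not show that the change would stay small on any further core.

The compounds shown carry only methyl or methoxy in this place on the ring. From the compounds shown here alone, what an amine, a carboxylic acid or a longer chain would do there remains open.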